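Swapping the Sulfonamide Substituent in an Antiproliferative Series

This account rests on a few compounds, and the source may have more. Where it says the series, first, only, none or still open, it means among the compounds named here.

Of the compounds shown here, three built on one shared core have been measured so far. Compound 1 `Cc1ccc(N(C)S(=O)(=O)C2CC3OC2C(c2ccc(NC(=O)CCCCCCC(=O)O)cc2)=C3c2ccc(O)cc2)cc1` gives 23200 nM in a functional assay on MCF7 cells (Homo sapiens) for antiproliferative activity, read by MTT assay, with a stated time of 72 h; on this read-out higher numbers stand for weaker inhibition and lower numbers for stronger inhibition. Compound 2 `COc1cccc(N(C)S(=O)(=O)C2CC3OC2C(c2ccc(NC(=O)CCCCCCC(=O)O)cc2)=C3c2ccc(O)cc2)c1` gives 39400 nM in this assay, and compound 3 `CN(c1ccc(Cl)cc1)S(=O)(=O)C1CC2OC1C(c1ccc(NC(=O)CCCCCCC(=O)O)cc1)=C2c1ccc(O)cc1` gives 13700 nM. Compound 2 thus carries the highest number of the three, but the step of a 1.7-fold higher number from compound 1 to compound 2 (0.23 log units; within the scatter) cannot be told from noise, whereas the step of a 2.9-fold lower number from compound 2 to compound 3 (0.46 log units; beyond the scatter) is a real, if modest, gain in potency.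

Compound 4 `CCN(c1cccc(C)c1)S(=O)(=O)C1CC2OC1C(c1ccc(NC(=O)CCCCCCC(=O)O)cc1)=C2c1ccc(O)cc1` is the next candidate. Relative to compound 2 the change is ethyl(3-methylphenyl)amino in place of (3-methoxyphenyl)(methyl)amino on a sulfonyl sulfur. Two measured steps speak to this position. The step of a 1.7-fold higher number from compound 1 to compound 2 (0.23 log units; within the scatter) exchanged one aryl group on the sulfonamide nitrogen for another and stayed within the scatter, and the step of a 1.7-fold lower number from compound 1 to compound 3 (0.23 log units; within the scatter), a single change on the aromatic ring, also stayed within the scatter; only a 2.9-fold lower number from compound 2 to compound 3 (0.46 log units; beyond the scatter) moved beyond it. Every alteration at this position has therefore been small, and the new change is expected to behave the same way: a step of about a 1.5-fold lower number from compound 2 to compound 4 (0.16 log units; within the scatter) is expected, which lies within the scatter. Compound 4 is accordingly estimated at 27000 nM, with a likely range from 11000 nM to 65000 nM.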

Compound 4, half-maximal inhibitory concentration: 31800 nM
Beside the measured number, compound 4's estimate is 1.2-fold (0.07 log units) below it; low and high end bracket the measured number.
By their numbers in this assay, from the lowest: compounds 3, 1, 4 and 2 (each within the scatter of the next, the first and the last beyond it).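

In this assay the step of a 1.2-fold lower number from compound 2 to compound 4 (0.09 log units; within the scatter) shows that the whole amino group on the sulfonyl sulfur can be exchanged without a readable result, even though the one hydrogen-bond acceptor of the leaving group is gone and an ethyl group now stands where a methyl group stood. The step of a 1.4-fold higher number from compound 1 to compound 4 (0.14 log units; within the scatter) also stays inside the scatter, whereas the step of a 2.3-fold higher number from compound 3 to compound 4 (0.37 log units; beyond the scatter) does not, so compound 3 parts from compound 2 and compound 4 but not from compound 1, which goes against any simple rule that the chloro group alone sets the number. No measurement at hand explains why the numbers fall this way.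

The ethyl group and the ring methyl group enter together, so the compounds shown cannot say what either does alone. Also open, on these data alone, is how a larger change on the sulfonamide nitrogen, such as a morpholine ring or a butyl chain, would read in this assay on this shared core.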